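The source may report more compounds than this note shows. Statements on the series, on what has been measured and on what is new or still open speak of the compounds shown alone.

Series notes. Compound 1 `CCc1ccc(SCc2ccc(/C=C/C(=O)Nc3ccccc3N)cc2)cc1` gives 60.7% in a functional assay on A549 cells (Homo sapiens) for inhibition, read by CCK-8 assay, with a stated time of 72 h, tested at 2 uM; on this read-out lower numbers stand for less inhibition of growth and higher numbers for more inhibition of growth at the one concentration tested. Compound 2 `Nc1ccccc1NC(=O)/C=C/c1ccc(CSc2ccc(C(F)(F)F)cn2)cc1` gives 51.7% in this assay, and compound 3 `Nc1ccccc1NC(=O)/C=C/c1ccc(CSc2ccc(F)cc2)cc1` gives 51.2% in this assay. Compound 3 sits within the usual scatter of both other compounds: a number 9.5 percentage points lower from compound 1 to compound 3 (within the scatter) and a number 0.5 percentage points lower from compound 2 to compound 3 (within the scatter). Compound 4 `Nc1ccccc1NC(=O)/C=C/c1ccc(CSCCc2ccccc2)cc1` is not yet measured; its change from compound 3 is phenethyl in place of 4-fluorophenyl on a sulfur. The earlier swaps on the same sulfur bear on this: a number 9 percentage points lower from compound 1 to compound 2 (within the scatter) and a number 0.5 percentage points lower from compound 2 to compound 3 (within the scatter), both within the scatter, so for compound 4 no step beyond the scatter is expected in this assay in either direction. For compound 4 the expected value is 52%, with a range of 38% to 66%. The step expected is a number 0.8 percentage points higher from compound 3 to compound 4 (within the scatter).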

Compound 4, percent growth inhibition at one concentration: 45.7%
The estimate for compound 4 lay 6.3 percentage points above the measured number, within the range that was stated.
By their numbers in this assay, from the lowest: compounds 4, 3, 2 and 1 (each within the scatter of the next, the first and the last beyond it).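

Going by these compounds alone, on the sulfur, phenethyl is the first group to give a step beyond the scatter in this assay, and only against 4-ethylphenyl (a number 15 percentage points lower from compound 1 to compound 4 (beyond the scatter)). Against the other two groups on that sulfur it stays within the scatter (a number 5.5 percentage points lower from compound 3 to compound 4 (within the scatter); a number 6 percentage points lower from compound 2 to compound 4 (within the scatter)), so the step depends on which compound serves as the reference. No measurement on hand accounts for these numbers. Open, on these data alone, is how an amine, a carboxylic acid or a longer chain on the same sulfur would read in this assay at the one concentration tested.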